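The source may hold more compounds than are shown below. What is called first, only, known or untested is meant among the compounds shown, and "the series" means these compounds.

Of the compounds shown here, three sharing one core have been measured in a functional assay on DU-145 cells (Homo sapiens) for cytotoxicity, read by MTT assay, with a stated time of 72 h; a higher number here means that more compound is needed for the effect, a lower number that less compound is needed. Compound 1 `CCc1cccc2c(OC)c(-c3occ(C)c3C(=S)OC)ccc12` gives 5.7 ug/mL in this assay. Compound 3 `CCc1cccc2c(OC)c(-c3occ(C)c3CO)ccc12` gives 7.2 ug/mL in this assay, and the step of a 1.3-fold higher number from compound 1 to compound 3 (0.10 log units; within the scatter) lies within the scatter, so these two cannot be told apart. Compound 2 `CCc1cccc2c(OC)c(-c3occ(C)c3C(=O)NC)ccc12` gives > 10 ug/mL in this assay, which is a limit of the assay rather than a number. The step of an at least 1.3-fold lower number from compound 2 to compound 3 (0.14 log units; that floor lies within the scatter) therefore has only a floor. Among the two compounds with a number, compound 3 stands highest, though only within the scatter of compound 1.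

Compound 4 `CCc1cccc2c(OC)c(-c3occ(C)c3COC)ccc12` is not yet measured. It differs from compound 3 by methyl in place of hydrogen on an oxygen on a saturated carbon. For the measured compounds named here, no measured step changes just this hydrogen; the steps that bear on it are those reaching the hydroxymethyl group of compound 3, a 1.3-fold higher number from compound 1 to compound 3 (0.10 log units; within the scatter) and an at least 1.3-fold lower number from compound 2 to compound 3 (0.14 log units; that floor lies within the scatter), both of which stayed within the scatter even though whole groups were exchanged. A smaller change there is therefore expected to move the number by no more than the scatter, in no set direction. Compound 4 is estimated at 8 ug/mL, with a range from 4 ug/mL to 16 ug/mL, meaning an expected step of a 1.1-fold higher number from compound 3 to compound 4 (0.05 log units; within the scatter) within the scatter. Since one of the three values is a limit (the limit of > 10 ug/mL in this assay, at which 1 of the 3 values shown sits), compound 4 too may return only a limit.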

Compound 4, concentration for half-maximal effect: > 10 ug/mL
Compound 4 was reported as a limit; the forecaster's own chance of this, stated with the estimate: 30%; middle value at least 1.2-fold (0.09 log units) away from the limit.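

In this assay, compound 4 gives > 10 ug/mL, which is a limit of the assay and not a number. For the compounds shown here, this is the first change made at this oxygen itself, hydroxy to methoxy, and it gives an at least 1.3-fold higher number from compound 3 to compound 4 (0.14 log units; that floor lies within the scatter), while exchanging the whole group on the aromatic carbon gives an at least 1.7-fold higher number from compound 1 to compound 4 (0.24 log units; that floor lies within the scatter), so a single added methyl is enough to leave the read-out without a number, yet neither floor can be told apart from the scatter. No size can be read for the step between compound 2 and compound 4, because both sit at the limit: the limit of > 10 ug/mL in this assay, at which 2 of the 4 values shown sit.

Going by these compounds, how far compound 2 and compound 4 lie past that limit stays open, and so does whether methoxymethyl in place of hydroxymethyl truly raises the number beyond the scatter. The compounds shown also leave open what a longer chain on this oxygen, such as ethoxymethyl, or an aminomethyl group or a carboxylic acid on the same aromatic carbon would do to the number.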